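This account rests on a few compounds, and the source may have more. Where it says the series, first, only, none or still open, it means among the compounds named here.

Measured so far:
Compound 1 `COCCOc1nc(N)nc2c1ncn2/C=C1/CC1(CO)CO`: in an ADME assay on Akata cells (Homo sapiens) for cytotoxicity, with a stated time of 7 days (on this read-out lower numbers stand for higher toxicity in this test and higher numbers for lower toxicity in this test), compound 1 gives only a limit, > 20000 nM.
Compound 2 `Nc1nc(NC2CCCCC2)c2ncn(/C=C3/CC3(CO)CO)c2n1`: in this assay compound 2 gives only a limit, > 24000 nM.
Compound 3 `CCCCCCOc1nc(N)nc2c1ncn2/C=C1/CC1(CO)CO`: in this assay compound 3 gives only a limit, > 20000 nM.

Compound 1 stands at a limit in this assay, and the two other values shown are limits as well, so nothing in the set ranks above or below anything else. Two of the three values sit at the limit of > 20000 nM in this assay, at which 2 of the 3 values shown sit, and one at the limit of > 24000 nM in this assay, at which 1 of the 3 values shown sits.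

The step considered here runs from compound 1 to compound 4 `Nc1nc(SCc2ccccc2)c2ncn(/C=C3/CC3(CO)CO)c2n1`: benzylsulfanyl in place of 2-methoxyethoxy on an aromatic carbon. The measured steps touching the same aromatic carbon are a step that the two limits leave unreadable from compound 1 to compound 2 and a step that the two limits leave unreadable from compound 2 to compound 3; the change along the chain, a step that the two limits leave unreadable from compound 1 to compound 3, is equally unreadable. None of the three steps yields a size, so no step beyond the scatter can be read in either direction, and the plain expectation is that compound 4 also remains at the limit. Compound 4 is expected to give about 20000 nM in this assay, within 8000 nM to 60000 nM. The step from compound 1 to compound 4 is accordingly estimated as a number no higher from compound 1 to compound 4 (the limit leaves the size open).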

Compound 4, half-maximal cytotoxic concentration: > 20000 nM
Compound 4: no number, only a limit; the forecaster's own chance of this, stated with the estimate: 70%; the middle value sits exactly at the limit.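

In this assay compound 4 gives only the limit > 20000 nM and no number, so its steps from compound 1, compound 2 and compound 3 cannot be read. As far as these compounds go, the concentration at which any of these four compounds becomes cytotoxic, and therefore any ranking among them, remains open.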